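The source may hold more compounds than are shown below. What is called first, only, known or untested is meant among the compounds shown, and "the series" means these compounds.

Compound 1 `Brc1cn2ccnc2c(-c2ccc3ncn(C4CCCCC4)c3c2)n1` stands lowest of the two numbers in hand: in a functional assay on CCRF-CEM cells (Homo sapiens) for inhibition, read by sulforhodamine B assay, with a stated time of 48 h, tested at 10 uM (a lower number here means less inhibition, a higher number more inhibition at the concentration tested (going by the name of the read-out)), compound 1 gives 7.68%, whereas compound 2 `c1ccc(-c2cn3ccnc3c(-c3ccc4ncn(C5CCCCC5)c4c3)n2)cc1` gives 81.3%, a step of a number 73.6 percentage points higher from compound 1 to compound 2 (beyond the scatter). Compound 3 `c1ccc2c(-c3cn4ccnc4c(-c4ccc5ncn(C6CCCCC6)c5c4)n3)cccc2c1` differs from compound 1 by naphthalen-1-yl in place of bromo on an aromatic carbon. Among the compounds with values here, the only step that bears on this exchanges the same bromo for phenyl, and it was large, so a second aromatic carbocycle at that place is expected to move the read-out in the same direction, by roughly a number 62.3 percentage points higher from compound 1 to compound 3 (beyond the scatter). For compound 3 the estimate is 70%, with a range from 35% to 92%.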

Compound 3, a percentage reported as inhibition, at one concentration (the size of the read-out at that concentration, not a potency): 17.5%
For compound 3 the middle estimate is 52.5 percentage points above the measured one; measured number below the stated range.
By their numbers in this assay, from the lowest: compounds 1 and 3 (each within the scatter of the next); then compound 2.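

In this assay naphthalen-1-yl at this aromatic carbon gives a number 9.8 percentage points higher from compound 1 to compound 3 (within the scatter) against bromo and a number 63.8 percentage points lower from compound 2 to compound 3 (beyond the scatter) against phenyl. The read-out at this position therefore depends on which aromatic carbocycle is attached, and the gain seen with phenyl does not carry over to naphthalen-1-yl. Nothing available explains this difference. Still open, on these data alone, is whether naphthalen-2-yl behaves like phenyl or like naphthalen-1-yl. Also open, as far as these compounds go, is whether a phenyl bearing a methoxy or an amine keeps the read-out of compound 2.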